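Compound 3 to compound 4: a cyano step

The compounds below may be only part of what the source reports. "The series", "measured", "known", "first", "only" and "open" are said of these compounds alone.

In an ADME assay on HCT-116 cells (Homo sapiens) for antiproliferative activity (on this read-out higher numbers stand for weaker inhibition and lower numbers for stronger inhibition), three compounds have been measured. Compound 1 (`COc1ccc(C(N)=O)cc1COc1ccc(Cl)c(C)c1`) gives > 50000 nM as a limit, not a number. Compound 2 (`COc1ccc(C(N)=O)cc1COc1ccc(Cl)cc1`) gives > 50000 nM as a limit, not a number. For the measured compounds named here, compound 3 (`COc1ccc(C(N)=O)cc1/C=C/c1ccccc1`) gives 36000 nM as the only actual number among the three. The rest of the picture is thin: the limit of > 50000 nM in this assay, at which 2 of the 3 values shown sit, is all the other two values offer.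

Compound 4 (`COc1ccc(C(N)=O)cc1/C=C/c1ccc(C#N)cc1`) comes from compound 3 by a single change (cyano in place of hydrogen on an aromatic carbon) and has not yet been measured. Going by the values given here, the one measured step (a step that the two limits leave unreadable from compound 1 to compound 2) concerns a different group and yields no size to carry over. No step beyond the scatter is therefore expected in this assay and no direction can be firmly expected. The expectation stays anchored on compound 3 at 36000 nM for want of any readable step. The estimated change (a 1.2-fold lower number from compound 3 to compound 4 (0.08 log units; within the scatter)) is small. For compound 4 the expected value is 30000 nM (estimated range 9000 nM to 60000 nM).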

Compound 4, half-maximal inhibitory concentration: 16000 nM
Beside the measured number, compound 4's estimate is 1.9-fold (0.27 log units) above it; measured number inside the range.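

In this assay, for the compounds shown here, this is the only readable step so far, a 2.3-fold lower number from compound 3 to compound 4 (0.35 log units; beyond the scatter) with cyano in place of hydrogen on an aromatic carbon. It shows that this place, on a six-membered aromatic ring of carbon only and para to a large group, responds to substitution, with a modest shift that lies beyond the scatter. The one earlier step cannot be read, so no size is available to set against this one, and the readable range stays narrow: the limit of > 50000 nM in this assay, at which 2 of the 4 values shown sit.

From the compounds shown here alone, whether the lower number is particular to cyano remains open, since an amine, a carboxylic acid or a methyl group at the same place could give a different step. Going by these compounds, it is also open whether cyano would give a step of similar size on the core of compound 1.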